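This account rests on a few compounds, and the source may have more. Where it says the series, first, only, none or still open, it means among the compounds named here.

Compound 1 `COc1ccc(Cn2cnc3c(N(C)c4ccc(OC)cc4)ncnc32)cc1` and compound 2 `COc1ccc(N(C)c2ncnc3c2ncn3Cc2ccc(OC)c(OC)c2)cc1` share the same core and were both tested in a functional assay on K562 cells (Homo sapiens) for antiproliferative activity, read by MTT assay, with a stated time of 48 h; a lower number here means a stronger inhibitor of growth, a higher number a weaker inhibitor of growth. In this assay compound 1 gives > 100000 nM, which is a limit of the assay rather than a number. In this assay compound 2 gives > 100000 nM, again a limit. Compound 2 differs from compound 1 by methoxy in place of hydrogen on an aromatic carbon, and the step that the two limits leave unreadable from compound 1 to compound 2 cannot be read because both values sit at the limit of > 100000 nM in this assay, at which 3 of the 3 values shown sit. Compound 3 `COc1cc(Cn2cnc3c(Cl)ncnc32)cc(OC)c1` is built on a different core. In this assay compound 3 gives > 100000 nM, which is a limit of the assay. The difference between the core of compound 1 and the core of compound 3 is not broken down here. Compound 4 `COc1cc(Cn2cnc3c(Cl)ncnc32)cc(OC)c1OC` has not yet been measured in this assay. It differs from compound 3 by methoxy in place of hydrogen on an aromatic carbon. Going by the values given here, this is the same kind of change as the one from compound 1 to compound 2, but the place is not the same: in compound 4 the entering group sits ortho to two methoxy groups and para to a large group, whereas in compound 2 it sits ortho to a methoxy group and meta to a large group. The expected step that the limit leaves unreadable from compound 3 to compound 4 is small, and that expectation rests on compound 1, compound 2 and compound 3 all sitting at the limit of > 100000 nM in this assay, at which 3 of the 3 values shown sit. For compound 4 in this assay the expected value is 150000 nM, most probably returned only as a limit, with a range from 40000 nM to 600000 nM.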

Compound 4, concentration for 50% growth inhibition: > 50000 nM
Compound 4 gave a limit, no number; the forecaster's own chance of this, stated with the estimate: 85%; the middle value is on the limit's open side.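

In this assay, no step can be read from compound 3 to compound 4: both results are limits of the assay, not numbers. All four values shown are limits, which leaves open how strongly any of these compounds inhibits growth, and what methoxy in place of hydrogen on an aromatic carbon does to that inhibition, whether on the core of compound 1 or on that of compound 3.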